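This account rests on a few compounds, and the source may have more. Where it says the series, first, only, none or still open, it means among the compounds named here.

In a functional assay on SW-620 cells (Homo sapiens) for antiproliferative activity, read by MTT assay, with a stated time of 24 h (on this read-out higher numbers stand for weaker inhibition and lower numbers for stronger inhibition), compound 2, with the structure `COc1ccccc1/C=C/C(=O)c1ccc(OC)c2c1OC(C)(C)C=C2`, gives > 10000 nM, which is a limit of the assay and not a number. Compound 1, with the structure `COc1ccc(C(=O)/C=C/c2ccccc2)c2c1C=CC(C)(C)O2`, gives > 10000 nM, again a limit of the assay. For the measured compounds named here, the one measured step, a step that the two limits leave unreadable from compound 1 to compound 2, stays unreadable in size and direction, and what the two values together show is simply (the limit of > 10000 nM in this assay, at which 2 of the 2 values shown sit). Compound 3, with the structure `COc1ccc(C(=O)/C=C/c2cc(Cl)ccc2O)c2c1C=CC(C)(C)O2`, has not yet been measured. It differs from compound 2 by 5-chloro-2-hydroxyphenyl in place of 2-methoxyphenyl on a double-bonded chain carbon bound to a double-bonded chain carbon. Going by the values given here, no measured step bears on this exchange, and the single step that exists cannot be read, so the data give no ground for a gain or a loss beyond the scatter in this assay. The expectation is that compound 3 behaves like the two compounds already seen and again reaches only the limit. The expected step, a step that the limit leaves unreadable from compound 2 to compound 3, is accordingly no larger than the scatter. Compound 3 is estimated to give about 12000 nM in this assay, within a range from 3000 nM to 40000 nM.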

Compound 3, half-maximal inhibitory concentration: 4230 nM
The estimate for compound 3 lay 2.8-fold (0.45 log units) above the measured number, and the stated range covers the measured number.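

Exchanging the ring on a double-bonded chain carbon bound to a double-bonded chain carbon can move the result in this assay: 5-chloro-2-hydroxyphenyl in place of 2-methoxyphenyl gives an at least 2.3-fold lower number from compound 2 to compound 3 (0.37 log units; beyond the scatter), and 5-chloro-2-hydroxyphenyl in place of phenyl gives an at least 2.3-fold lower number from compound 1 to compound 3 (0.37 log units; beyond the scatter). As far as these compounds go, both steps start from a limit of the assay and not a number, so their full size stays unknown, and the step from compound 1 to compound 2 still cannot be read. Compound 3 is the only one of the three compounds that gives a number, so it offers the first measured value for this position, while the others remain at the edge of the assay: the limit of > 10000 nM in this assay, at which 2 of the 3 values shown sit.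

The compounds shown do not separate the chlorine from the hydroxy group, so it remains open whether one of them alone or only the two together account for these steps. They also leave open how the result would change with an amine or a carboxylic acid on this ring, or with a longer chain in this place.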